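The source may report more compounds than this note shows. Statements on the series, on what has been measured and on what is new or still open speak of the compounds shown alone.

Of the compounds shown here, three sharing one core have been measured. Compound 1 `Nc1ccccc1NC(=O)c1ccc(CSC(=S)N2CCN(c3ccc(F)cc3)CC2)cc1` carries 4-fluorophenyl on an amine nitrogen in a ring, and in a functional assay on MGC-803 cells (Homo sapiens) for antiproliferative activity, read by CCK-8 assay, with a stated time of 72 h, tested at 8 uM (a lower number here means a weaker effect, a higher number a stronger effect of the compound at the concentration tested), compound 1 gives 48.7%. Compound 2 `Nc1ccccc1NC(=O)c1ccc(CSC(=S)N2CCN(Cc3ccccc3)CC2)cc1` gives 19.7%, a step of a number 29 percentage points lower from compound 1 to compound 2 (beyond the scatter). Compound 3 `Nc1ccccc1NC(=O)c1ccc(CSC(=S)N2CCN(Cc3cccnc3)CC2)cc1` gives 64.6%, the highest of the three numbers; it stands a number 15.9 percentage points higher from compound 1 to compound 3 (beyond the scatter) and a number 44.9 percentage points higher from compound 2 to compound 3 (beyond the scatter), both beyond the scatter.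

Compound 4 `N#Cc1ccc(N2CCN(C(=S)SCc3ccc(C(=O)Nc4ccccc4N)cc3)CC2)cc1` has not yet been measured in this assay. It differs from compound 3 in one place: 4-cyanophenyl in place of (pyridin-3-yl)methyl on an amine nitrogen in a ring.

Among the compounds with values here, two measured steps bear on this change. The step from compound 1 to compound 3, a number 15.9 percentage points higher from compound 1 to compound 3 (beyond the scatter), exchanged 4-fluorophenyl on the ring nitrogen for (pyridin-3-yl)methyl; compound 4 moves the other way, back to a six-membered aromatic ring of carbon only on that nitrogen. The step of a number 44.9 percentage points higher from compound 2 to compound 3 (beyond the scatter) shows that the ring within the group on this nitrogen can shift the number by a large amount. Within the data shown here, no measured compound carries 4-cyanophenyl, so how it compares with 4-fluorophenyl has no measured basis. A modest decrease, roughly the reverse of the step from compound 1 to compound 3, is therefore expected: compound 4 is estimated at 50%, within 30% to 70%, an expected step of a number 14.6 percentage points lower from compound 3 to compound 4 (beyond the scatter).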

Compound 4, a percentage reported as inhibition, at one concentration (the size of the read-out at that concentration, not a potency): 37.6%
The estimate for compound 4 lay 12.4 percentage points above the measured number, and the stated range covers the measured number.
By their numbers in this assay, from the lowest: compound 2; then compound 4; then compound 1; then compound 3.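

In this assay, within the data shown here, the step of a number 11.1 percentage points lower from compound 1 to compound 4 (beyond the scatter) is the first measured change on the aromatic ring itself, with cyano in place of fluoro on an aromatic carbon, and it shows that the group on that ring moves the number even when the ring stays bound to the same ring nitrogen. The steps of a number 27 percentage points lower from compound 3 to compound 4 (beyond the scatter) and a number 17.9 percentage points higher from compound 2 to compound 4 (beyond the scatter) place 4-cyanophenyl between (pyridin-3-yl)methyl and benzyl, so the two groups with a chain carbon do not fall on one side of the two directly attached aryl groups, and the swap of (pyridin-3-yl)methyl for 4-cyanophenyl cannot be read as a single effect of removing that carbon. Nothing given here accounts for these steps.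

As far as these compounds go, it remains open how pyridin-3-yl set directly on the ring nitrogen would compare, which would separate the ring nitrogen of the pyridine from the chain carbon. Also open, from the compounds shown here alone, is whether 4-methoxyphenyl, 4-carboxyphenyl or 4-cyanobenzyl would continue or break the order seen so far.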